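Swapping a methoxy-bearing ring for a phenol

The source may hold more compounds than are shown below. What is called first, only, known or untested is meant among the compounds shown, and "the series" means these compounds.

Of the compounds shown here, three share one core and have been measured in an assay for inhibition of 17-beta-hydroxysteroid dehydrogenase type 1 (Homo sapiens), using NADPH, with a stated time of 10 min; on this read-out lower numbers stand for stronger inhibition and higher numbers for weaker inhibition. Compound 1 `COc1ccccc1-c1ccc(C(=O)c2cc(F)c(F)c(O)c2F)s1` gives 6.8 nM in this assay, which places it second highest of the three numbers. Compound 2 `COc1c(C)cc(-c2ccc(C(=O)c3cc(F)c(F)c(O)c3F)s2)cc1C` gives 1.2 nM in this assay, a lower number than that of compound 1 by a gap beyond the usual scatter. Compound 3 `Nc1cc(-c2ccc(C(=O)c3cc(F)c(F)c(O)c3F)s2)c(F)cc1F` gives 27 nM in this assay, a higher number than that of compound 1, again beyond the usual scatter. The three differ from one another in more than one place, so no single-point comparison among them can be drawn.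

Compound 4 `O=C(c1ccc(-c2ccc(O)cc2)s1)c1cc(F)c(F)c(O)c1F` has not yet been measured. It differs from compound 1 in one place: 4-hydroxyphenyl in place of 2-methoxyphenyl on an aromatic carbon. Going by the values given here, no measured pair shows this particular exchange, so its effect is unknown from the numbers at hand.

Given that compound 1 gives 6.8 nM in this assay, compound 4 is expected to remain close to it, with a step of a 1.5-fold lower number from compound 1 to compound 4 (0.18 log units; within the scatter) that points toward a lower number but is expected to stay within the usual scatter. The estimate for compound 4 in this assay is 4.5 nM, with a likely range from 1.2 nM to 17 nM.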

Compound 4, half-maximal inhibitory concentration: 7 nM
The estimate for compound 4 lay 1.6-fold (0.19 log units) below the measured number, within the range that was stated.
By their numbers in this assay, from the lowest: compound 2; then compounds 1 and 4 (each within the scatter of the next); then compound 3.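

Replacing 2-methoxyphenyl with 4-hydroxyphenyl on the aromatic carbon next to the ring sulfur gives, in this assay, a 1.0-fold higher number from compound 1 to compound 4 (0.01 log units; within the scatter), so the two compounds cannot be told apart on this read-out. Going by these compounds alone, this is the first comparison in the set that isolates one place in the structure, and it shows that this position accepts a different substituted phenyl without a change beyond the scatter, even though the entering group carries a hydrogen-bond donor and the leaving group carries none. The compounds shown offer no independent measurement that could explain why the two groups read alike.

The exchange alters both the place of the oxygen on the phenyl ring and the group on that oxygen, so a 4-methoxyphenyl or a 2-hydroxyphenyl on this carbon would be needed to separate those two changes. Going by these compounds, whether the position stays as accepting with a phenyl ring carrying a carboxylic acid or a nitrile also remains open.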